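A few compounds are considered here, and "the series" means these few. Any claim that something is new, unique, unknown or untested is made for them only; others in the source may bear on it.

Compound 1 `Nc1ccccc1NC(=O)c1ccc(NC(=S)NCc2cccc(F)c2)cc1` was tested in an assay on isolated protein for inhibition of Nicotinamide phosphoribosyltransferase (Homo sapiens), read by fluorescence, with stated times of 5 min and 15 min (a higher number here means a weaker inhibitor, a lower number a stronger inhibitor), where compound 1 gives only a limit, > 2000 nM. Compound 2 `Nc1ccccc1NC(=O)c1ccc(CNC(=O)c2cc3cccnc3[nH]2)cc1` likewise returns only a limit in this assay, at > 2000 nM. Both results sit at the limit of > 2000 nM in this assay, at which 2 of the 2 values shown sit, so compound 1 stands at the edge of the assay rather than on a number. Compound 3 `Nc1ccccc1NC(=O)c1ccc(NC(=S)NCc2ccc(Cl)nc2)cc1` differs from compound 1 by 6-chloropyridin-3-yl in place of 3-fluorophenyl on a saturated chain carbon bound to an amide-type nitrogen. For the measured compounds named here, no measured step covers this change, and the step from compound 1 to compound 3 is expected to stay within the scatter, a step that the limit leaves unreadable from compound 1 to compound 3. Compound 3 is estimated at 3000 nM, between 1000 nM and 10000 nM, most probably again reported only as a limit.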

Compound 3, half-maximal inhibitory concentration: > 2000 nM
Compound 3 gave a limit, no number (the forecaster's own chance of this, stated with the estimate: 75%); the middle value does not contradict the limit.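

In this assay, for the compounds shown here, compound 1 and compound 3 both give only a limit, so no step between them can be read: (the limit of > 2000 nM in this assay, at which 3 of the 3 values shown sit). The compounds shown leave open how strongly any of them inhibits the enzyme.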